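Compound 2 and the Change at Its Stereocentre

The source may report more compounds than this note shows. Statements on the series, on what has been measured and on what is new or still open speak of the compounds shown alone.

- Compound 1 `C=C1C(=O)OC[C@H]1CCOC(=O)Nc1ccc(Cl)cc1`: 390 nM
- Compound 2 `C=C1C(=O)OC[C@H]1CCOC(=O)Nc1ccc(C(=O)OCCCC)cc1`: 430 nM
- Compound 3 `C=C1C(=O)OC[C@H]1CCOC(=O)Nc1ccc(OC)cc1`: 710 nM

All three compounds were measured in a functional assay on RAW264.7 cells (Mus musculus) for inhibition, with a stated time of 30 min; on this read-out higher numbers stand for weaker inhibition and lower numbers for stronger inhibition. In this assay compound 2 gives 430 nM, and this value lies within the scatter of the other two. The nearest is a 1.1-fold higher number from compound 1 to compound 2 (0.04 log units; within the scatter), and the furthest is a 1.7-fold higher number from compound 2 to compound 3 (0.22 log units; within the scatter).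

The next compound to be measured is compound 4 `C=C1C(=O)OC[C@@H]1CCOC(=O)Nc1ccc(C(=O)OCCCC)cc1`. The change is the two compounds have the same atoms and bonds and differ only in configuration as drawn: 1 of 1 stereo elements differ; a stereocentre at a saturated ring carbon is drawn S in compound 2 and R in compound 4. Nothing leaves and nothing enters.

The measured steps bear on this change only indirectly. Each of them exchanges a group on an aromatic carbon and leaves the configuration as drawn untouched. Besides the two steps above, there is a 1.8-fold higher number from compound 1 to compound 3 (0.26 log units; within the scatter). All three remain within the scatter, but none of them tests a change of configuration, and the data contain no such comparison. The direction is therefore uncertain and the range must stay wide.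

The estimated step is a 1.4-fold higher number from compound 2 to compound 4 (0.14 log units; within the scatter), which is not expected to exceed the scatter. For compound 4 the expected value is 600 nM, with an estimated range of 200 nM to 1800 nM.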

Compound 4, half-maximal inhibitory concentration: 860 nM
The estimate for compound 4 lay 1.4-fold (0.16 log units) below the measured number; measured number inside the range.
By their numbers in this assay, from the lowest: compounds 1, 2, 3 and 4 (each within the scatter of the next, the first and the last beyond it).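

The pair gives the first direct test of the stereocentre at the saturated ring carbon: in this assay, drawing it R in place of S gives a 2.0-fold higher number from compound 2 to compound 4 (0.30 log units; within the scatter). The comparison isolates this one stereocentre because nothing else separates the pair: the fact that compounds 2 and 4 differ only in the configuration as drawn. The step stays within the scatter, so the pair does not establish that configuration at this carbon matters for inhibition in this assay, nor does it show that the two forms are equivalent, and the reading applies only to the butoxycarbonyl series.

Compound 1 and compound 3 are shown only with the S configuration as drawn, so it remains open whether the same change would give a comparable step with chloro or methoxy on the aromatic carbon. Also open, on these data alone, is how a carboxylic acid or an amine in that place would read in either configuration, and whether repeated measurements would separate the R and S forms more clearly than this single pair does.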